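A few compounds are considered here, and "the series" means these few. Any claim that something is new, unique, unknown or untested is made for them only; others in the source may bear on it.

Measured in a functional assay on cells (Neuron, Rattus norvegicus) for inhibition, read by LDH release, with a stated time of 24 h; a higher number here means a weaker inhibitor, a lower number a stronger inhibitor:
compound 1 `COc1ccc(N(C)c2nc(=O)c3cccnc3s2)cc1`: 3400 nM
compound 2 `Cc1ccc(N(C)c2nc(=O)c3cccnc3s2)cc1`: 10000 nM

Compound 2, at 10000 nM, has the higher of the two numbers, which makes it the weaker inhibitor of this pair. Compound 3 `CN(c1ccc(F)cc1)c1nc(=O)c2cccnc2s1` keeps the shared core and alters one group: fluoro in place of methyl on an aromatic carbon. This is fluoro in place of methyl on an aromatic carbon, para to a large group. Among the compounds with values here, only one measured step concerns this place: a 2.9-fold higher number from compound 1 to compound 2 (0.47 log units; beyond the scatter), a modest change for methyl in place of methoxy. Within the data shown here, it shows that the number in this assay can move with a swap here, but no fluoro compound has been measured, so it gives no firm direction. The expected change is therefore small, and the estimated step is a 1.4-fold lower number from compound 2 to compound 3 (0.15 log units; within the scatter). For compound 3 the estimated value is 7000 nM, with an expected range of 2500 nM to 20000 nM.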

Compound 3, half-maximal inhibitory concentration: 7200 nM
For compound 3 the middle estimate is 1.0-fold (0.01 log units) below the measured one, and the stated range covers the measured number.
By their numbers in this assay, from the lowest: compound 1; then compounds 3 and 2 (each within the scatter of the next).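

In this assay, putting fluoro in place of methyl on this aromatic carbon gives a 1.4-fold lower number from compound 2 to compound 3 (0.14 log units; within the scatter), so this assay does not separate these two groups at this position. Methoxy now stands apart from fluoro as well as from methyl, with a 2.1-fold higher number from compound 1 to compound 3 (0.33 log units; beyond the scatter), a modest step that is smaller than a 2.9-fold higher number from compound 1 to compound 2 (0.47 log units; beyond the scatter) but points the same way, so among these three compounds the lower number belongs to the methoxy compound alone. No measured evidence is available to explain why methoxy differs from the other two groups.

Going by these compounds, it remains open whether an amine, a hydroxyl or a longer chain such as ethoxy on this carbon would match compound 1 or fall with compound 2 and compound 3. How far a number lower than that of compound 1 can be reached through changes at this position is also unresolved.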